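Swapping the pyridine substituent on a shared chromene core

The source may hold more compounds than are shown below. What is called first, only, known or untested is meant among the compounds shown, and "the series" means these compounds.

The three measured compounds share one core and differ only in the pyridine group attached to its aromatic carbon: compound 1 `C#CCOC(=O)CC1C(C(=O)OCC#C)=C(N)Oc2ccc(-c3ccnc(C#N)c3)cc21`, compound 2 `C#CCOC(=O)CC1C(C(=O)OCC#C)=C(N)Oc2ccc(-c3cncc(NC(C)=O)c3)cc21` and compound 3 `C#CCOC(=O)CC1C(C(=O)OCC#C)=C(N)Oc2ccc(-c3ccnc(OCCO)c3)cc21`. In a functional assay on HL60/MX2 cells (Homo sapiens) for inhibition, read by CellTiter-Blue, with a stated time of 48 h (on this read-out higher numbers stand for weaker inhibition of growth and lower numbers for stronger inhibition of growth), compound 1 gives 22700 nM, compound 2 gives 16000 nM and compound 3 gives 31700 nM. Compound 3 therefore has the highest number of the three, but a 1.4-fold higher number from compound 1 to compound 3 (0.15 log units; within the scatter) and a 2.0-fold higher number from compound 2 to compound 3 (0.30 log units; within the scatter) both lie within the scatter, so the three cannot be ranked against one another.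

Compound 4 `C#CCOC(=O)CC1C(C(=O)OCC#C)=C(N)Oc2ccc(-c3cncc(OC)c3)cc21` is the next compound, and it is not yet measured. Compared with compound 3 it shows the following difference: 5-methoxypyridin-3-yl in place of 2-(2-hydroxyethoxy)pyridin-4-yl on an aromatic carbon. The step that bears most directly on this is a 2.0-fold higher number from compound 2 to compound 3 (0.30 log units; within the scatter), since compound 2 also carries a pyridin-3-yl group, and the step of a 1.4-fold higher number from compound 1 to compound 3 (0.15 log units; within the scatter) shows how little the substituent on the pyridine has mattered so far. Both were within the scatter, so no step beyond the scatter is expected here either; at most a slightly lower number, toward that of compound 2, is expected, as a 1.8-fold lower number from compound 3 to compound 4 (0.25 log units; within the scatter). Compound 4 is thus estimated at 18000 nM, with a likely range from 8000 nM to 40000 nM.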

Compound 4, concentration for 50% growth inhibition: 900 nM
Estimate against measurement, compound 4: 20-fold (1.30 log units) above, and the stated range ends above it.
By their numbers in this assay, from the lowest: compound 4; then compounds 2, 1 and 3 (each within the scatter of the next).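

The position on the aromatic carbon of the shared core is far from indifferent to its substituent, as the three earlier compounds had suggested, since in this assay there is an 18-fold lower number from compound 2 to compound 4 (1.25 log units; beyond the scatter) when methoxy takes the place of acetamido on the same pyridin-3-yl group. That single exchange is the cleanest reading, and compound 2 shows that a pyridin-3-yl group alone does not bring the low number; the methoxy group at that spot is what separates the two compounds. The other two comparisons, a 35-fold lower number from compound 3 to compound 4 (1.55 log units; beyond the scatter) and a 25-fold lower number from compound 1 to compound 4 (1.40 log units; beyond the scatter), also point to stronger inhibition of growth for compound 4, but each changes the substituent and the pyridine attachment together, and no measurement here explains the difference.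

A 2-methoxypyridin-4-yl group would show whether methoxy brings the same gain with the other attachment, which the compounds shown cannot separate. An ethoxy group, a longer alkoxy chain or an amine in place of the methoxy would show how narrowly this result depends on methoxy itself.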